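This account rests on a few compounds, and the source may have more. Where it says the series, first, only, none or still open, it means among the compounds named here.

Measured compounds:
compound 1, `CCc1ccc2[nH]c(=O)c(CN(Cc3ccc(OCOC)cc3)Cc3ccc(C(C)(C)C)cc3)cc2c1` — > 10000 nM
compound 2, `Cc1ccc2[nH]c(=O)c(CN(Cc3ccc(OCC(=O)O)cc3)Cc3ccc(C(C)(C)C)cc3)cc2c1` — > 10000 nM
compound 3, `CCc1ccc2[nH]c(=O)c(CN(Cc3ccc(C(C)(C)C)cc3)C(C)c3ccc(OC)cc3)cc2c1` — > 5000 nM

In a toxicity assay on MDCK cells (Canis lupus familiaris) for cytotoxicity, read by crystal violet staining, with a stated time of 48 h (on this read-out higher numbers stand for lower toxicity in this test and lower numbers for higher toxicity in this test), compound 1 gives > 10000 nM, which is a limit of the assay and not a number. Compound 2 gives > 10000 nM in this assay, again only a limit. Compound 3 gives > 5000 nM in this assay, also a limit. Compound 2 therefore stands at the limit of > 10000 nM in this assay, at which 2 of the 3 values shown sit, while compound 3 stands at the limit of > 5000 nM in this assay, at which 1 of the 3 values shown sits. Within the data shown here, the only step between measured compounds that differ in one place is a step that the two limits leave unreadable from compound 1 to compound 3, and with both ends sitting at a limit its size cannot be read. Compound 4, `Cc1ccc2[nH]c(=O)c(CN(Cc3ccc(C(C)(C)C)cc3)C(C)c3ccc(N(C)C)c(Cl)c3)cc2c1`, differs from compound 2 by 1-(3-chloro-4-(dimethylamino)phenyl)ethyl in place of 4-(carboxymethoxy)benzyl on an amine nitrogen. Among the measured compounds shown here, no measured step resolves this change, since the one step that is known, a step that the two limits leave unreadable from compound 1 to compound 3, is itself unreadable. Compound 4 is therefore expected to remain at or beyond the limits seen so far, with an expected step of a number no higher from compound 2 to compound 4 (the limit leaves the size open). Compound 4 is estimated at 10000 nM, with a range from 4000 nM to 30000 nM.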

Compound 4, half-maximal cytotoxic concentration: 9800 nM
For compound 4 the middle estimate is 1.0-fold (0.01 log units) above the measured one; measured number inside the range.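

In this assay, among these compounds, compound 4 gives 9800 nM, the only value shown that is a number and not a limit, so a toxicity reading now exists for a compound with 1-(3-chloro-4-(dimethylamino)phenyl)ethyl on the amine nitrogen. Compound 2 gives only a limit of the assay and not a number: the limit of > 10000 nM in this assay, at which 2 of the 4 values shown sit. The change gives an at least 1.0-fold lower number from compound 2 to compound 4 (0.00 log units; that floor lies within the scatter), so replacing 4-(carboxymethoxy)benzyl with this group shows no shift beyond the scatter, though the limit leaves room for a larger one.

The compounds shown leave open which part of the entering group, the chlorine, the dimethylamino group or the branching methyl, would carry any shift. Also open, going by these compounds, is how a morpholine in place of the dimethylamino group, or a fluorine in place of the chlorine, would read in this assay.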